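This account rests on a few compounds, and the source may have more. Where it says the series, first, only, none or still open, it means among the compounds named here.

Compound 1 `O=C(NC1CCCCC1)Oc1cccc(-c2ccc(F)cc2)c1` is the reference point of this series. In an assay on cell membranes for binding affinity to Fatty-acid amide hydrolase 1 (Rattus norvegicus) (a higher number here means a weaker inhibitor, a lower number a stronger inhibitor), compound 1 gives 65 nM, the lowest of the three numbers measured. Compound 2 `O=C(NC1CCCCC1)Oc1cccc(-c2cccc(-c3ccccc3)c2)c1` gives 565 nM in this assay, and compound 3 `O=C(NC1CCCCC1)Oc1cccc(-c2cccc(Cc3ccccc3)c2)c1` gives 1860 nM. Among the measured compounds shown here, the only step between two measured compounds that differ in a single place is a 3.3-fold higher number from compound 2 to compound 3 (0.52 log units; beyond the scatter); the gap between compound 1 and compound 2, which differ in the whole outer ring, is not a single-place step, and the two values alone show a clearly higher number for compound 2.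

Compound 4 `O=C(NC1CCCCC1)Oc1cccc(-c2cccc(CO)c2)c1` is not yet measured. It differs from compound 1 as follows: 3-(hydroxymethyl)phenyl in place of 4-fluorophenyl on an aromatic carbon. For the measured compounds named here, no measured step bears directly on this exchange, since the one step known concerns benzyl against phenyl on a different outer ring. What the numbers do show is that every variation of the outer ring away from compound 1 has given a higher number, clearly so in compound 2. On that basis a moderate rise is expected, a 3.4-fold higher number from compound 1 to compound 4 (0.53 log units; beyond the scatter), with wide uncertainty. Compound 4 is therefore estimated at 220 nM in this assay, within a range from 60 nM to 800 nM.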

Compound 4, half-maximal inhibitory concentration: 8.67 nM
Compound 4: middle estimate off by 25-fold (1.40 log units), on the high side, and the stated range ends above it.
By their numbers in this assay, from the lowest: compound 4; then compound 1; then compound 2; then compound 3.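

Until now every change of the outer ring away from compound 1 had given a higher number, but 3-(hydroxymethyl)phenyl in place of 4-fluorophenyl runs the other way, with a 7.5-fold lower number from compound 1 to compound 4 (0.87 log units; beyond the scatter) in this assay and the lowest number of the four compounds. The outer ring therefore does not have to carry 4-fluorophenyl for a low number, and what stands on this ring counts for much: hydroxymethyl in place of phenyl gives a 65-fold lower number from compound 2 to compound 4 (1.81 log units; beyond the scatter) on an aromatic carbon, and hydroxy in place of phenyl gives a 210-fold lower number from compound 3 to compound 4 (2.33 log units; beyond the scatter) on a saturated chain carbon, both larger than the step that separates compound 2 and compound 3. Nothing among the data shown explains why this exchange lowers the number.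

From the compounds shown here alone, whether the hydroxy group itself is what matters stays open, since a plain methyl, a methoxymethyl, an aminomethyl or a carboxylic acid in the same place would be needed to tell. Also open, going by these compounds, is whether hydroxymethyl would give a similar number in the place held by fluorine in compound 1.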